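A few compounds are considered here, and "the series" means these few. Any claim that something is new, unique, unknown or untested is made for them only; others in the source may bear on it.

Compound 1, `CC(C)N(Cc1cccc(OCCCCCC(=O)O)c1)C(=O)c1ccc(-c2cccc(-c3ccccc3)c2)cc1`, gives > 26000 nM in an ADME assay on BJ cells (Homo sapiens) for cytotoxicity, read by CellTiter-Glo and resazurin assay, with a stated time of 72 h; a higher number here means that more compound is needed for the effect, a lower number that less compound is needed; this is a limit of the assay, not a number.
Compound 2, `Cc1nnc(-c2cccc(-c3ccc(C(=O)N(Cc4cccc(OCCCCCC(=O)O)c4)C(C)C)cc3)c2)o1`, gives > 26000 nM in this assay; this too is a limit of the assay.

Both measured compounds share one core and differ only in the group attached to it. The step that the two limits leave unreadable from compound 1 to compound 2 therefore cannot be read in size, since both ends sit at the limit of > 26000 nM in this assay, at which 2 of the 2 values shown sit. Compound 2 thus stands at the limit, with no value on either side to mark where it truly lies.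

Compound 3, `CC(C)N(Cc1cccc(OCCCCCC(=O)O)c1)C(=O)c1ccc(-c2c[nH]c3ccccc23)cc1`, differs from compound 2 in one place: 1H-indol-3-yl in place of 3-(5-methyl-1,3,4-oxadiazol-2-yl)phenyl on an aromatic carbon. Among the measured compounds shown here, the only measured step bearing on this position is the one from compound 1 to compound 2, and its size is unreadable, so there is nothing to show that a change at this position moves the readout out of the region at the limit.

Compound 3 is therefore expected to give 26000 nM in this assay, with a range of 9000 nM to 80000 nM. The expected step of a number no higher from compound 2 to compound 3 (the limit leaves the size open) is estimated to be none beyond the scatter, most likely with compound 3 reported as a limit again.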

Compound 3, half-maximal effective concentration: > 26000 nM
Compound 3: no number, only a limit (the forecaster's own chance of this, stated with the estimate: 80%); the middle value sits exactly at the limit.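

No step can be read in size among compound 1, compound 2 and compound 3, since all three end at the same assay limit: the limit of > 26000 nM in this assay, at which 3 of the 3 values shown sit. The compounds shown leave open where the true value of each lies in this assay, and whether any change at this position moves the readout away from that limit.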